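Fluoro for hydroxy on the side chain: working notes

This account rests on a few compounds, and the source may have more. Where it says the series, first, only, none or still open, it means among the compounds named here.

The series shares the core of compound 1 `COc1nc(C)c(CCO)c(OC)n1` and is followed in a functional assay on NCI-H460 cells (Homo sapiens) for antiproliferative activity, read by MTT assay, with a stated time of 24 h; on this read-out higher numbers stand for weaker inhibition and lower numbers for stronger inhibition. In this assay compound 1 gives > 100000 nM, which is a limit of the assay and not a number. Compound 2 `COc1nc(Cl)nc(C)c1CCO` in this assay gives > 100000 nM, again only a limit. The step that the two limits leave unreadable from compound 1 to compound 2 cannot be read because both values sit at the limit of > 100000 nM in this assay, at which 2 of the 2 values shown sit. Compound 2 thus stands at the limit, with no number of its own in this assay.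

Compound 3 `COc1nc(Cl)nc(C)c1CCF` differs from compound 2 by fluoro in place of hydroxy on a saturated chain carbon, two bonds along the chain from an aromatic carbon. Going by the values given here, no measured step bears on this change; the single measured step is unreadable, and nothing in the values seen points to a gain beyond the scatter. Compound 3 is therefore expected to remain at the limit, with a number no higher from compound 2 to compound 3 (the limit leaves the size open) expected to be small. For compound 3 the estimate in this assay is 100000 nM, with a range from 30000 nM to 300000 nM.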

Compound 3, half-maximal inhibitory concentration: > 100000 nM
Compound 3 was reported as a limit (the forecaster's own chance of this, stated with the estimate: 80%); the middle value sits exactly at the limit.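

In this assay compound 3 gives > 100000 nM, a limit of the assay and not a number. No step can be read between compound 2 and compound 3: the limit of > 100000 nM in this assay, at which 3 of the 3 values shown sit.

The compounds shown leave open whether fluoro in place of hydroxy changes the activity at all, since none of them has a value that is a number.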